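Swapping a Methyl for Aryl Groups on a Shared Core

This account rests on a few compounds, and the source may have more. Where it says the series, first, only, none or still open, it means among the compounds named here.

Measured so far:
- compound 1 `CCCCCCCCc1ccc(OCC(=O)Cn2nnc(C)n2)cc1`: 27 nM
- compound 2 `CCCCCCCCc1ccc(OCC(=O)Cn2nnc(-c3cccnc3)n2)cc1`: 23 nM
- compound 3 `CCCCCCCCc1ccc(OCC(=O)Cn2nnc(-c3cccs3)n2)cc1`: 32 nM

All three compounds were tested in an assay on microsomes from brain for inhibition of Fatty-acid amide hydrolase 1 (Rattus norvegicus), read by fluorescence and HPLC, with a stated time of 60 min; on this read-out lower numbers stand for stronger inhibition and higher numbers for weaker inhibition. Among the three numbers, compound 1 holds the second highest; its nearest neighbour is compound 2, and the gap to compound 3 is the widest, yet every gap stays within the usual scatter, so no ordering among the three can be claimed.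

Two measured steps start from compound 1 and change the same place. Replacing the methyl with pyridin-3-yl gives a 1.2-fold lower number from compound 1 to compound 2 (0.07 log units; within the scatter), and replacing it with thiophen-2-yl gives a 1.2-fold higher number from compound 1 to compound 3 (0.07 log units; within the scatter). Neither aryl group moved the number beyond the scatter.

The next compound, compound 4 `CCCCCCCCc1ccc(OCC(=O)Cn2nnc(-c3ccc(C(=O)O)cc3)n2)cc1`, differs from compound 1 as follows: 4-carboxyphenyl in place of methyl on an aromatic carbon. This again puts an aromatic ring where the methyl stood, as in compound 2 and compound 3, but the entering group is larger than either of those and carries a hydrogen-bond donor and acceptor that they lack. Because a 1.2-fold lower number from compound 1 to compound 2 (0.07 log units; within the scatter) and a 1.2-fold higher number from compound 1 to compound 3 (0.07 log units; within the scatter) were both flat, a small step is expected, but the wider range reflects the larger change. Compound 4 is expected to give 35 nM (range 12 nM to 120 nM), a step of a 1.3-fold higher number from compound 1 to compound 4 (0.11 log units; within the scatter) that is estimated to stay close to the scatter.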

Compound 4, half-maximal inhibitory concentration: 90 nM
For compound 4 the middle estimate is 2.6-fold (0.41 log units) below the measured one; low and high end bracket the measured number.
By their numbers in this assay, from the lowest: compounds 2, 1 and 3 (each within the scatter of the next); then compound 4.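

This position on the shared core is not indifferent to what it carries: in this assay, 4-carboxyphenyl gives a 3.3-fold higher number from compound 1 to compound 4 (0.52 log units; beyond the scatter), the first step from compound 1 at this place that lies beyond the scatter. The same group also separates from both smaller aromatic rings, with a 2.8-fold higher number from compound 3 to compound 4 (0.45 log units; beyond the scatter) and a 3.9-fold higher number from compound 2 to compound 4 (0.59 log units; beyond the scatter), so at this place a new aromatic ring does not by itself leave the number unchanged, although all three steps are modest. The data offer no measurement that accounts for this rise.

Compound 4 brings in a phenyl ring and a carboxylic acid together, and the compounds shown cannot tell which of the two goes with the higher number. A plain phenyl group would test the ring without the acid, and a methyl ester in place of the carboxylic acid would show whether the acid's hydrogen matters.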